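A few compounds are considered here, and "the series" means these few. Any claim that something is new, unique, unknown or untested is made for them only; others in the source may bear on it.

Compound 1 `O=C1NCCN1c1ccc(S(=O)(=O)Nc2ccc(I)cc2)cc1` is the starting point here. In a functional assay on M21 cells (Homo sapiens) for antiproliferative activity, read by sulforhodamine B assay, with a stated time of 48 h (a lower number here means a stronger inhibitor, a higher number a weaker inhibitor), compound 1 gives 260 nM. Two relatives carry the same core with a different group on the sulfonamide nitrogen: compound 2 `CCc1cccc(NS(=O)(=O)c2ccc(N3CCNC3=O)cc2)c1` gives 82 nM, and compound 3 `Cc1cccc(NS(=O)(=O)c2ccc(N3CCNC3=O)cc2)c1C` gives 110 nM. Of these three numbers, compound 1 has the highest, so it is the weakest inhibitor of the set. The step of a 3.2-fold lower number from compound 1 to compound 2 (0.50 log units; beyond the scatter) and the step of a 2.4-fold lower number from compound 1 to compound 3 (0.37 log units; beyond the scatter) both go the same way, each a modest gain. Between the two alkyl-bearing relatives the step of a 1.3-fold higher number from compound 2 to compound 3 (0.13 log units; within the scatter) is too small to call a change.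

Compound 4 `CC(C)Cc1ccc(NS(=O)(=O)c2ccc(N3CCNC3=O)cc2)cc1` differs from compound 1 at one place: isobutyl in place of iodo on an aromatic carbon. As in the two measured steps, an iodine is traded for carbon-only alkyl substitution on the phenyl ring, which makes those steps the relevant guide. They suggest a modest lowering of the number rather than none, though an isobutyl group is not a direct repeat of either measured change. The expected step is a 2.2-fold lower number from compound 1 to compound 4 (0.34 log units; beyond the scatter). Compound 4 is therefore estimated at 120 nM, with a likely range from 50 nM to 300 nM.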

Compound 4, half-maximal inhibitory concentration: > 1000 nM
Compound 4 was reported as a limit; the forecaster's own chance of this, stated with the estimate: 3%; middle value at least 8.3-fold (0.92 log units) away from the limit.
By their numbers in this assay, from the lowest: compounds 2 and 3 (each within the scatter of the next); then compound 1. At a limit, above all of these: compound 4.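

In this assay, isobutyl in place of iodo on an aromatic carbon gives an at least 3.8-fold higher number from compound 1 to compound 4 (0.58 log units; beyond the scatter), which runs opposite to the earlier 3.2-fold lower number from compound 1 to compound 2 (0.50 log units; beyond the scatter) and a 2.4-fold lower number from compound 1 to compound 3 (0.37 log units; beyond the scatter). Trading the iodine for carbon-only substitution on this phenyl ring therefore does not lower the number by itself: compounds 2 and 3 follow that trend, while compound 4 goes against it, with the 4 carbon atoms of isobutyl standing on the ring carbon para to a large group where compound 1 has a single iodine atom. The reading for compound 4 is a limit and not a number: the limit of > 1000 nM in this assay, at which 1 of the 4 values shown sits.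

The compounds shown leave open what a methyl or an ethyl group would give at this same place, so it cannot be told whether any alkyl group here raises the number or whether this is specific to isobutyl. An amine or a carboxylic acid at this place would also test whether groups other than iodo and isobutyl are tolerated there.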